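The compounds below may be only part of what the source reports. "The series", "measured", "known", "first", "only" and "open" are said of these compounds alone.

In a functional assay on HCT-116 cells (Homo sapiens) for cytotoxicity, read by MTT assay, with a stated time of 72 h (a higher number here means a weaker inhibitor, a lower number a stronger inhibitor), compound 1 `CS(=O)(=O)Oc1c(C(=O)NCc2ccc(F)cc2)nc(Br)c2cccnc12` gives > 20000 nM, which is a limit of the assay and not a number. Compound 3 `CC(C)(C)OC(=O)N1CCN(c2c(C(=O)NCc3ccc(F)cc3)nc(Br)c3cccnc23)CC1` gives > 10000 nM, again a limit and not a number. For compound 2 `O=C(NCc1ccc(F)cc1)c1nc(NCCO)c2cccnc2c1O` the entry reads "not determined" (no result reported). Compound 1 therefore stands at a limit, and the series offers no measured potency to anchor on.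

Compound 4 `Nc1ccc(Nc2c(C(=O)NCc3ccc(F)cc3)nc(Br)c3cccnc23)cc1` changes one group on the core of compound 1, with (4-aminophenyl)amino in place of (methylsulfonyl)oxy on an aromatic carbon, para to a bromo group ((4-aminophenyl)amino in place of (methylsulfonyl)oxy on an aromatic carbon). Among the compounds with values here, no measured step scales this change.

The limit of compound 3, > 10000 nM, gives no measured sign of potency, so only a moderate move toward lower numbers is expected in this assay, and a further limit remains possible. The estimated step is an at least 3.3-fold lower number from compound 1 to compound 4 (0.52 log units; beyond the scatter). For compound 4 the expected value is 6000 nM, with an estimated range of 1500 nM to 20000 nM.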

Compound 4, half-maximal inhibitory concentration: 10000 nM
Compound 4: middle estimate off by 1.7-fold (0.22 log units), on the low side, within the range that was stated.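

In this assay compound 4 gives 10000 nM, the only actual number among the compounds shown, so a group at this position on the shared core can give a readable value. Compound 1 stands at a limit and not a number: the limit of > 20000 nM in this assay, at which 1 of the 4 values shown sits. From the compounds shown here alone, the change to (4-aminophenyl)amino in place of (methylsulfonyl)oxy gives an at least 2.0-fold lower number from compound 1 to compound 4 (0.30 log units; that floor lies within the scatter), so this pair alone does not establish a gain, and its true size remains unknown.

Going by these compounds, it remains open whether the value in compound 4 goes with the aromatic ring or with its amino group; a plain phenylamino group, or a carboxylic acid in place of that amino group, would separate the two. The bromo group is also common to compound 1, compound 3 and compound 4, so its contribution cannot be read.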